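Compound 2 to compound 3: bromo gives way to methoxymethyl

The source may hold more compounds than are shown below. What is called first, only, known or untested is meant among the compounds shown, and "the series" means these compounds.

In a functional assay on NCI-H460 cells (Homo sapiens) for cytotoxicity, read by MTT assay, with a stated time of 72 h (on this read-out higher numbers stand for weaker inhibition and lower numbers for stronger inhibition), compound 1 `O=c1[nH]/c(=C\c2ncc[nH]2)c(=O)[nH]/c1=C\c1cccc(Oc2ccc(F)cc2)c1` gives > 1000 nM, which is a limit of the assay and not a number. Within the data shown here, compound 2 `O=c1[nH]/c(=C\c2ccc(Br)o2)c(=O)[nH]/c1=C\c1cccc(Oc2ccc(F)cc2)c1` gives 361 nM, the only true number so far. Putting 5-bromofuran-2-yl in place of 1H-imidazol-2-yl gave an at least 2.7-fold lower number from compound 1 to compound 2 (0.44 log units; beyond the scatter). Compound 3 `COCc1ccc(/C=c2\[nH]c(=O)/c(=C/c3cccc(Oc4ccc(F)cc4)c3)[nH]c2=O)o1` has methoxymethyl in place of bromo on an aromatic carbon. Among the measured compounds shown here, the one measured step, an at least 2.7-fold lower number from compound 1 to compound 2 (0.44 log units; beyond the scatter), exchanged the whole group and left this substituent untested, so it offers only weak guidance on size and none on direction. No shift beyond the scatter is therefore expected in this assay. The expected change is a 1.2-fold higher number from compound 2 to compound 3 (0.07 log units; within the scatter). For compound 3, the estimated value is 420 nM, with an expected range of 130 nM to 1200 nM.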

Compound 3, half-maximal inhibitory concentration: 14 nM
The estimate for compound 3 lay 30-fold (1.48 log units) above the measured number, and the stated range ends above it.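

With the ring kept, the carbon next to the ring oxygen proves to be a sensitive position in this assay: methoxymethyl in place of bromo gives a 26-fold lower number from compound 2 to compound 3 (1.41 log units; beyond the scatter). The earlier step exchanged the whole group, whereas this one shows that the substituent on the five-membered aromatic ring can alone shift the number well beyond the scatter. Set against the imidazole-bearing compound, 5-(methoxymethyl)furan-2-yl gives an at least 71-fold lower number from compound 1 to compound 3 (1.85 log units; beyond the scatter), a size that is only a bound: the limit of > 1000 nM in this assay, at which 1 of the 3 values shown sits.

The compounds shown do not separate the contribution of the oxygen in methoxymethyl from that of its chain. From the compounds shown here alone, how an ethyl, hydroxymethyl or aminomethyl group would read on the same carbon remains open.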